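Replacing fluoro with nitro on the aryl ketone

The compounds below may be only part of what the source reports. "The series", "measured", "known", "first", "only" and "open" are said of these compounds alone.

Compound 1 `CC(=O)c1ccc2c(c1)C(n1ccccc1=O)=CC(C)(C)O2`: 6.65
Compound 2 `CC1(C)C=C(n2ccccc2=O)c2cc(C(=O)c3ccccc3F)ccc2O1`: 6.34

In a functional assay (trachea) with Rattus norvegicus as the target (on this read-out higher numbers stand for higher potency (the scale is a negative logarithm) and lower numbers for lower potency), compound 1 gives 6.65 and compound 2 gives 6.34. Compound 2 stands lowest of the two, the change being a number 0.31 log units lower from compound 1 to compound 2 (beyond the scatter). Compound 3 `CC1(C)C=C(n2ccccc2=O)c2cc(C(=O)c3ccccc3[N+](=O)[O-])ccc2O1` differs from compound 2 by nitro in place of fluoro on an aromatic carbon. Going by the values given here, no measured step swaps one group for another on the six-membered aromatic ring of carbon only; the only step known, a number 0.31 log units lower from compound 1 to compound 2 (beyond the scatter), exchanges the group on the carbonyl carbon and is modest. A step of no more than the scatter is therefore expected, a number 0.04 log units lower from compound 2 to compound 3 (within the scatter). Compound 3 is estimated at 6.3, within 5.8 to 6.8.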

Compound 3, logarithm of the reciprocal of the active concentration, log(1/C): 5.64
Beside the measured number, compound 3's estimate is 0.66 log units above it, outside the stated range (below it).
By their numbers in this assay, from the lowest: compound 3; then compound 2; then compound 1.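

Going by these compounds alone, this is the first swap measured on this aromatic carbon, and in this assay the choice of group clearly matters: nitro in place of fluoro lowers the number (a number 0.70 log units lower from compound 2 to compound 3 (beyond the scatter)). The change from the methyl ketone to the 2-nitrophenyl ketone is a large loss (a number 1.01 log units lower from compound 1 to compound 3 (beyond the scatter)), greater than the one seen with 2-fluorophenyl (a number 0.31 log units lower from compound 1 to compound 2 (beyond the scatter)).

As far as these compounds go, whether an amine or a methoxy group on this carbon would keep or lower the number remains open. Nothing shown explains the drop.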